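Does an iodine swap change a leukaemia cell read-out?

This account rests on a few compounds, and the source may have more. Where it says the series, first, only, none or still open, it means among the compounds named here.

In a functional assay on cells (leukaemia cell line, Homo sapiens) for inhibition, read by sulforhodamine B assay, with a stated time of 48 h (on this read-out higher numbers stand for lower toxicity in this test and lower numbers for higher toxicity in this test), compound 1 `O=S(=O)(Nc1cccc(Cl)c1)c1ccc(-c2cnc(C3CC3)o2)cc1` gives > 100000 nM as a limit, not a number. Compound 2 `O=S(=O)(Nc1cc(F)cc(Cl)c1)c1ccc(-c2cnc(C3CC3)o2)cc1` gives > 100000 nM as a limit too. This is the limit of > 100000 nM in this assay, at which 2 of the 2 values shown sit, and leaves compound 2 without an exact number. Among the compounds with values here, the one measured step is a step that the two limits leave unreadable from compound 1 to compound 2 and offers no size to carry forward. Compound 3 `O=S(=O)(Nc1ccc(I)c(Cl)c1)c1ccc(-c2cnc(C3CC3)o2)cc1` has 3-chloro-4-iodophenyl in place of 3-chloro-5-fluorophenyl on a sulfonamide nitrogen. Within the data shown here, no measured step covers this swap, so no shift beyond the scatter is expected in this assay and no direction can be given. Compound 3 is expected near 100000 nM with an estimated range from 30000 nM to 150000 nM and a report of only a limit remains the likeliest outcome. That estimate means an expected a number no higher from compound 2 to compound 3 (the limit leaves the size open) for now.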

Compound 3, concentration lethal to 50% of the cells: > 100000 nM
Compound 3: a limit, no number; the forecaster's own chance of this, stated with the estimate: 80%; the middle value sits exactly at the limit.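

No new step can be read for compound 3 against compound 1 or compound 2, because all three stop at a limit rather than a number: the limit of > 100000 nM in this assay, at which 3 of the 3 values shown sit. The compounds shown leave open where their true values lie and whether the fluoro or iodo swaps change this read-out at all.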